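The compounds below may be only part of what the source reports. "The series", "measured", "known", "first", "only" and "open" are said of these compounds alone.

Working notes on the series. Compound 1 `CCOC(=O)c1c(C)[nH]c(=O)c(C#N)c1-c1ccc([N+](=O)[O-])cc1`, compound 2 `CCOC(=O)c1c(C)[nH]c(=O)c(C#N)c1-c1ccc(C#N)cc1` and compound 3 `CCOC(=O)c1c(C)[nH]c(=O)c(C#N)c1-c1ccc(F)cc1` share one core and differ only in the group carried on the aryl ring. In a functional assay on A549 cells (Homo sapiens) for inhibition, read by MTT assay, with a stated time of 24 h (a higher number here means a weaker inhibitor, a lower number a stronger inhibitor), compound 1 sits at a limit of the assay, > 100000 nM. Compound 2 likewise sits at a limit in this assay, > 100000 nM. Compound 3 gives a number, 15400 nM in this assay. The step that the two limits leave unreadable from compound 1 to compound 2 is unreadable; the steps of an at least 6.4-fold lower number from compound 1 to compound 3 (0.81 log units; beyond the scatter) and an at least 6.4-fold lower number from compound 2 to compound 3 (0.81 log units; beyond the scatter) are both beyond the scatter, read against (the limit of > 100000 nM in this assay, at which 2 of the 3 values shown sit). Within the data shown here, compound 3 therefore stands as the only compound of the three with a number, the other two being limits.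

Compound 4 `CCOC(=O)c1c(C)[nH]c(=O)c(C#N)c1-c1cccs1` is not yet measured. It differs from compound 3 by thiophen-2-yl in place of 4-fluorophenyl on an aromatic carbon. Among the measured compounds shown here, none of the measured steps covers this change: all three swap a group on the aryl ring, none exchanges the ring itself. No direction can be read from them, so in this assay compound 4 is expected near compound 3, estimated at 25000 nM with a range of 6000 nM to 100000 nM. The expected step is a 1.6-fold higher number from compound 3 to compound 4 (0.21 log units; within the scatter), with a fair chance the assay returns only a limit.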

Compound 4, half-maximal inhibitory concentration: 20100 nM
Estimate against measurement, compound 4: 1.2-fold (0.09 log units) above, within the range that was stated.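

In this assay, the position opposite the ring nitrogen tolerates exchange of the aryl ring itself, not just of the group it carries: a 1.3-fold higher number from compound 3 to compound 4 (0.12 log units; within the scatter). Thiophen-2-yl in place of 4-fluorophenyl therefore gives a second compound with a number rather than a limit, and a five-membered aromatic ring with a sulfur atom serves here as well as the fluorinated six-membered ring. The two numbers still stand against two limits: the limit of > 100000 nM in this assay, at which 2 of the 4 values shown sit.

The compounds shown leave open whether an amine or a carboxylic acid on the aryl ring would give a number or a limit, and whether a ring such as furan-2-yl would match thiophen-2-yl. Also open, from the compounds shown here alone, is how a longer chain in place of the ethoxycarbonyl group would read at this level.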